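Compound 1 at the limit, compound 4 unmeasured

This account rests on a few compounds, and the source may have more. Where it says the series, first, only, none or still open, it means among the compounds named here.

Compound 1 `COc1c(OCc2cnoc2C)cc(O)c2c(=O)cc(-c3ccccc3)oc12`: > 100000 nM
Compound 2 `CCCCNCCCCOc1c(O)cc(O)c2c(=O)cc(-c3ccccc3)oc12`: "not determined" (no result reported)
Compound 3 `COc1c(O)cc(O)c2c(=O)cc(-c3ccc(C)cc3)oc12`: "not determined" (no result reported)

In a functional assay on A549 cells (Homo sapiens) for cytotoxicity, read by MTT assay, with a stated time of 48 h (a lower number here means a stronger inhibitor, a higher number a weaker inhibitor), compound 1 gives > 100000 nM, which is a limit of the assay and not a number. The series therefore has no measured potency to work from, only (the limit of > 100000 nM in this assay, at which 1 of the 3 values shown sits). Compound 2 has "not determined" (no result reported) in this assay. Compound 3 has "not determined" (no result reported) there. Within the data shown here, neither offers a comparison, and no measured step shows how far a change of this kind can move the result.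

The next compound is compound 4 `COc1c(OCCCCN2CCCCC2)cc(O)c2c(=O)cc(-c3ccccc3)oc12`. It keeps the core of compound 1, but (5-methyl-1,2-oxazol-4-yl)methyl gives way to 4-(piperidin-1-yl)butyl: 3-(piperidin-1-yl)propyl in place of 5-methyl-1,2-oxazol-4-yl on a saturated chain carbon bound to an oxygen on an aromatic ring. In the narrower reading, 3-(piperidin-1-yl)propyl stands in place of 5-methyl-1,2-oxazol-4-yl on a saturated chain carbon bound to an oxygen on an aromatic ring.

Compound 1 at > 100000 nM leaves room in only one direction, so any measurable result would mean stronger inhibition. A step beyond the usual scatter is expected, though compound 4 may also return only a limit. The expected change is an at least 4.0-fold lower number from compound 1 to compound 4 (0.60 log units; beyond the scatter). For compound 4 the estimated value is 25000 nM, with an expected range of 6000 nM to 100000 nM.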

Compound 4, half-maximal inhibitory concentration: 1150 nM
Compound 4: the middle estimate sits 22-fold (1.34 log units) above what was measured, and the stated range ends above it.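

The group on this oxygen turns out to decide whether the shared core registers at all in this assay: replacing 5-methyl-1,2-oxazol-4-yl with 3-(piperidin-1-yl)propyl on a saturated chain carbon bound to an oxygen on an aromatic ring gives an at least 86-fold lower number from compound 1 to compound 4 (1.93 log units; beyond the scatter). Among these compounds, compound 4 thus supplies the first real number, and with it the first sign that this position can move the result by a large margin. On these data alone, compound 1 still marks only the lower end of that comparison, so the true size of the step stays open, and its value is a limit of the assay, the only such entry among the compounds so far: the limit of > 100000 nM in this assay, at which 1 of the 4 values shown sits.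

The change removes a five-membered aromatic ring and brings in a longer chain ending in a six-membered non-aromatic ring with one nitrogen, so the compounds shown cannot say which of these parts carries the gain. A shorter chain ending in the same piperidine, a morpholine at the chain end, or an open-chain diethylamine would separate chain length from the ring and its nitrogen.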